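Changing the Amine Substituent in a Low-Toxicity Series

A few compounds are considered here, and "the series" means these few. Any claim that something is new, unique, unknown or untested is made for them only; others in the source may bear on it.

Measured compounds:
- compound 1, `COc1ccc([C@H]2CC(=O)N(c3ccc(C)cc3)C2)cc1OC1CCCC1`, in a functional assay on HEK293 cells (Homo sapiens) for cytotoxicity (on this read-out higher numbers stand for lower toxicity in this test and lower numbers for higher toxicity in this test), compound 1 gives > 10000 nM, a limit of the assay.
- compound 2, `COc1ccc([C@H]2CC(=O)N(c3ccc(S(C)(=O)=O)cc3)C2)cc1OC1CCCC1`, compound 2 gives > 10000 nM, also a limit.
- compound 3, `COc1ccc([C@H]2CC(=O)N(c3cccc(NCC4CCOC4)c3)C2)cc1OC1CCCC1`, compound 3 gives > 10000 nM, again a limit.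

Compound 3 thus stands at the same limit as the other two, so its position among them cannot be ranked; every shown value sits at the limit of > 10000 nM in this assay, at which 3 of the 3 values shown sit. Among the compounds with values here, the only measured single-point step, a step that the two limits leave unreadable from compound 1 to compound 2, cannot be read for size or direction.

Compound 4, `COc1ccc([C@H]2CC(=O)N(c3cccc(NS(=O)(=O)c4cccc(C)c4)c3)C2)cc1OC1CCCC1`, is not yet measured. It differs from compound 3 by (3-methylphenyl)sulfonyl in place of (oxolan-3-yl)methyl on a nitrogen on an aromatic ring. Within the data shown here, no measured step covers this change, and none of the measured steps resolves any size at all. The expectation therefore rests only on the shared result: the step of a number no higher from compound 3 to compound 4 (the limit leaves the size open) is expected to be none beyond the scatter, and compound 4 is expected to give 10000 nM, with a range from 3000 nM to 30000 nM, most probably again reported as a limit.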

Compound 4, half-maximal cytotoxic concentration: > 10000 nM
Compound 4: only a limit was reported; the forecaster's own chance of this, stated with the estimate: 80%; the middle value sits exactly at the limit.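

The result for compound 4 in this assay is a limit, as is that for compound 3, so the step between them cannot be read for size or direction: the limit of > 10000 nM in this assay, at which 4 of the 4 values shown sit.

The compounds shown leave open how the four rank against one another in this assay.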